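A Dimethylamino Swap in a Microsomal Inhibition Series

This account rests on a few compounds, and the source may have more. Where it says the series, first, only, none or still open, it means among the compounds named here.

Of the compounds shown here, three have been measured in a functional assay on microsomes for inhibition, with a stated time of 1 h; on this read-out lower numbers stand for stronger inhibition and higher numbers for weaker inhibition. Compound 1 `CSc1nc(-c2ccco2)c(C#N)c(=O)n1C` gives 90 ug/mL in this assay. Compound 2 `CCOC(=O)c1cnn(-c2nc(-c3ccc(Cl)cc3)c(C#N)c(=O)n2C)c1N` gives 88 ug/mL in this assay. Compound 3 `COc1ccc(-c2nc(NN)n(C)c(=O)c2C#N)cc1` gives 39 ug/mL in this assay. Compound 2 thus holds the second highest of the three numbers; its value and that of compound 1 lie within the scatter of each other, so nothing separates the two, whereas the number of compound 3 sits below that of compound 2 by a margin beyond the scatter.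

Among the measured compounds shown here, no two measured compounds differ in only one place, so no single change has yet been followed. Compound 4 `CCOC(=O)c1cnn(-c2nc(-c3ccc(N(C)C)cc3)c(C#N)c(=O)n2C)c1N` is the new entry, and it differs from compound 2 in one place: dimethylamino in place of chloro on an aromatic carbon. The exchanged group sits on an aromatic carbon of a six-membered aromatic ring of carbon only. For the measured compounds named here, nothing measured bears on this exchange, and the three known numbers span a narrow band. The step is therefore expected to be small, with no clear direction, and the estimate corresponds to a 1.3-fold lower number from compound 2 to compound 4 (0.10 log units; within the scatter) in this assay. On that basis compound 4 is estimated at 70 ug/mL in this assay, with a range from 30 ug/mL to 160 ug/mL.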

Compound 4, half-maximal inhibitory concentration: 111 ug/mL
For compound 4 the middle estimate is 1.6-fold (0.20 log units) below the measured one; the range from low to high includes it.
By their numbers in this assay, from the lowest: compound 3; then compounds 2, 1 and 4 (each within the scatter of the next).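

In this assay the exchange of 4-chlorophenyl for 4-(dimethylamino)phenyl comes to a 1.3-fold higher number from compound 2 to compound 4 (0.10 log units; within the scatter) and so gives the series its first single change that can be followed, and compound 2 and compound 4 cannot be told apart. At this place, on an aromatic carbon para to a large group, dimethylamino with its 3 heavy atoms and 1 hydrogen-bond acceptor reads the same as chloro with its 1 heavy atom and no acceptor. No accompanying measurement offers an explanation for this result.

This single pair says nothing about how other groups would read at the same place, such as a carboxylic acid, a primary amine or a longer alkoxy chain, so it cannot show whether the number is insensitive to this position in general. As far as these compounds go, the other parts of the shared core also remain open, among them whether a carboxylic acid or an amide in place of the ethyl ester would shift the number beyond the scatter.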